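Removing the aryl methyl in the hydroxylactam series

This account rests on a few compounds, and the source may have more. Where it says the series, first, only, none or still open, it means among the compounds named here.

- compound 1 `Cc1ccc(-c2cn(CCC3(O)NC(=O)C(OCc4ccccc4)=C3OCc3ccccc3)nn2)cc1`: 82200 nM
- compound 2 `O=C1O/C(=C\Cn2cc(Cc3ccccc3)nn2)C(OCc2ccccc2)=C1OCc1ccccc1`: 29200 nM
- compound 3 `CCCc1cn(CCC2(O)C(OCc3ccccc3)=C(OCc3ccccc3)C(=O)N2CCC)nn1`: > 100000 nM

In a functional assay on MDA-MB-231 cells (Homo sapiens) for antiproliferative activity, read by MTT assay, with a stated time of 24 h (a lower number here means a stronger inhibitor, a higher number a weaker inhibitor), compound 1 gives 82200 nM, the higher of the two numbers reported, with compound 2 at 29200 nM, and the gap between them lies beyond the scatter. Compound 3 returns a limit of the assay, > 100000 nM, and no number. The assay limit, (the limit of > 100000 nM in this assay, at which 1 of the 3 values shown sits), is where that value sits.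

Compound 4 `O=C1NC(O)(CCn2cc(-c3ccccc3)nn2)C(OCc2ccccc2)=C1OCc1ccccc1` is not yet measured. It differs from compound 1 by hydrogen in place of methyl on an aromatic carbon. Within the data shown here, no step between measured compounds touches this position, so the size of the move is not anchored by the data; the shared core, the benzyloxy groups and the triazole are all retained, and only a single carbon is taken from the ring that carries the triazole. The expectation is a step from compound 1 to compound 4 of a 1.1-fold higher number from compound 1 to compound 4 (0.04 log units; within the scatter) in this assay, in either direction but not clearly beyond the scatter. On that basis compound 4 is estimated at 90000 nM in this assay, within 35000 nM to 250000 nM, with a fair chance that the assay returns only its limit.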

Compound 4, half-maximal inhibitory concentration: 21100 nM
For compound 4 the middle estimate is 4.3-fold (0.63 log units) above the measured one; the whole stated range lies above it.
By their numbers in this assay, from the lowest: compounds 4 and 2 (each within the scatter of the next); then compound 1. At a limit, above all of these: compound 3.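

Among these compounds, the step from 4-methylphenyl to phenyl on the triazole gives, in this assay, a 3.9-fold lower number from compound 1 to compound 4 (0.59 log units; beyond the scatter) and is the only step that can be read so far. It shows that this position is not silent: on an aromatic carbon para to a large group, the exchange of a single methyl for hydrogen is enough to move the antiproliferative read-out beyond the scatter, and here the lower number goes with hydrogen. Among the compounds shown here, nothing measured so far accounts for the size of this step.

The compounds shown hold only methyl or hydrogen at this carbon, so it remains open whether a fluorine, a methoxy group or an amine in the same place would fall on the side of compound 4 or of compound 1, and a single pair gives a direction at this position but no trend. Also open, on these data alone, is whether the same exchange on the phenyl ring would give a step of similar size with a different group on the lactam nitrogen, such as a longer chain, or on a different core.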